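Terpyridine-like series: moving one pyridine nitrogen

This account rests on a few compounds, and the source may have more. Where it says the series, first, only, none or still open, it means among the compounds named here.

Measured in a functional assay on HCT-15 cells (Homo sapiens) for antiproliferative activity; on this read-out higher numbers stand for weaker inhibition of growth and lower numbers for stronger inhibition of growth:
- Compound 1 `c1ccc(-c2cc(-c3ccsc3)cc(-c3cccnc3)n2)nc1`: > 100 ug/mL, a limit of the assay
- Compound 2 `c1ccc(-c2cc(-c3cccs3)cc(-c3ccccn3)n2)nc1`: 0.11 ug/mL

Among the measured compounds shown here, compound 2 holds the only actual number in this assay so far, so it has no measured neighbour to be ranked against. The other result is not a number: the limit of > 100 ug/mL in this assay, at which 1 of the 2 values shown sits.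

The next compound to be tested is compound 3 `c1ccc(-c2cc(-c3cccs3)cc(-c3cccnc3)n2)nc1`. It has pyridin-3-yl in place of pyridin-2-yl on an aromatic carbon, and the two have the same atoms, joined differently. The change sits next to the ring nitrogen of the shared core.

For the measured compounds named here, no single-place step has been measured, so the size of this one is an expectation with little support. Compound 1, which also carries pyridin-3-yl, gives > 100 ug/mL, and this is a limit. That compound differs from compound 3 in its sulfur-ring attachment, so it only hints at the direction. A sizeable move towards weaker inhibition of growth is expected, and the estimated change is a 91-fold higher number from compound 2 to compound 3 (1.96 log units; beyond the scatter). For compound 3 the expected value is 10 ug/mL, within an estimated range of 0.5 ug/mL to 100 ug/mL.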

Compound 3, concentration for 50% growth inhibition: 56.1 ug/mL
Beside the measured number, compound 3's estimate is 5.6-fold (0.75 log units) below it; the range from low to high includes it.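

In this assay, among the compounds shown here, pyridin-3-yl in place of pyridin-2-yl on an aromatic carbon next to the ring nitrogen gives a 510-fold higher number from compound 2 to compound 3 (2.71 log units; beyond the scatter), the first single-place step, so with the same atoms joined differently, the attachment of this one pyridine ring alone separates strong from weak inhibition of growth. Thiophen-2-yl in place of thiophen-3-yl, with pyridin-3-yl held constant, gives an at least 1.7-fold lower number from compound 1 to compound 3 (0.25 log units; that floor lies within the scatter), which sets only a floor on that step and leaves its true size unsettled. That step cannot go further, as compound 1 carries a limit of the assay and not a number: the limit of > 100 ug/mL in this assay, at which 1 of the 3 values shown sits.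

From the compounds shown here alone, what stays open is how pyridin-4-yl or a plain phenyl at this position would read against compound 2 and compound 3, which would show whether pyridin-2-yl is unique here. Also open, going by these compounds, is whether the thiophene attachment matters once pyridin-2-yl is kept, and whether furan-2-yl can stand in for thiophen-2-yl.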